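Swapping the pyridyl of compound 2 for an aminopyridazinyl

The compounds below may be only part of what the source reports. "The series", "measured", "known", "first", "only" and "open" are said of these compounds alone.

Of the compounds shown here, three sharing one core have been measured in an ADME assay on microsomes from liver (Rattus norvegicus) for metabolic stability; a lower number here means slower removal, a higher number faster removal of the compound. Compound 1 `Cc1csc(-c2cc(NC(=O)c3ccc(OCc4ccccn4)cc3)c(C)cc2C)n1` gives 147 mL.min-1.g-1. Compound 2 `Cc1cc(C)c(-c2ccccn2)cc1NC(=O)c1ccc(OCc2ccccn2)cc1` gives 296 mL.min-1.g-1, and compound 3 `Cc1cc(C)c(-c2cccnc2)cc1NC(=O)c1ccc(OCc2ccccn2)cc1` gives 78 mL.min-1.g-1. Compound 2 stands at the top of these three numbers, with compound 1 within the scatter of it and compound 3 beyond it, as the steps of a 2.0-fold higher number from compound 1 to compound 2 (0.30 log units; within the scatter) and a 3.8-fold lower number from compound 2 to compound 3 (0.58 log units; beyond the scatter) show; the step of a 1.9-fold lower number from compound 1 to compound 3 (0.28 log units; within the scatter) is within the scatter.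

Compound 4 `Cc1cc(C)c(-c2ccc(N)nn2)cc1NC(=O)c1ccc(OCc2ccccn2)cc1` differs from compound 2 in one place: 6-aminopyridazin-3-yl in place of pyridin-2-yl on an aromatic carbon. Among the measured compounds shown here, no measured step exchanges this pair of groups, so only the general behaviour of the site bears on it. Every exchange of the aryl group at this site so far has moved this assay by a small to modest amount, and the largest of them, from compound 2, went downward. For compound 4 a modest downward step is therefore expected, a 2.0-fold lower number from compound 2 to compound 4 (0.30 log units; within the scatter), giving an estimated 150 mL.min-1.g-1 with a range from 60 mL.min-1.g-1 to 380 mL.min-1.g-1.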

Compound 4, intrinsic clearance in microsomes: 8 mL.min-1.g-1
Estimate against measurement, compound 4: 19-fold (1.27 log units) above; the measured number lies below the stated range.
By their numbers in this assay, from the lowest: compound 4; then compounds 3, 1 and 2 (each within the scatter of the next, the first and the last beyond it).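

At this site the aryl group can move this assay much further than the earlier exchanges showed: 6-aminopyridazin-3-yl gives a step (a 37-fold lower number from compound 2 to compound 4 (1.57 log units; beyond the scatter)) well beyond the largest earlier one (a 3.8-fold lower number from compound 2 to compound 3 (0.58 log units; beyond the scatter)). Among the compounds shown here, the new group also falls clearly under the other two aryl groups, both the pyridin-3-yl (a 9.8-fold lower number from compound 3 to compound 4 (0.99 log units; beyond the scatter)) and the 4-methyl-1,3-thiazol-2-yl (an 18-fold lower number from compound 1 to compound 4 (1.26 log units; beyond the scatter)), so the low end of this assay at this position lies well under what the earlier compounds reached. Nothing measured here accounts for this drop.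

The entering group brings both a second ring hetero atom and an amino group, and the compounds shown do not separate the two. A plain pyridazin-3-yl or a 6-aminopyridin-3-yl at this site would tell them apart.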